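Oxime in place of oxadiazole on the shared core

The source may hold more compounds than are shown below. What is called first, only, known or untested is meant among the compounds shown, and "the series" means these compounds.

Among the measured compounds shown here, in a functional assay for activation of Alpha-1A adrenergic receptor (Homo sapiens), read by calcium flux (on this read-out lower numbers stand for an effect already at smaller amounts and higher numbers for an effect only at larger amounts of compound), compound 1 `Cc1noc(-c2ccccc2NCC2=NCCN2)n1` gives 661 nM, the higher of the two numbers known. Compound 2 `Nc1nccc(-c2ccccc2NCC2=NCCN2)n1` gives 42.7 nM in this assay, so compound 1 is the weaker of the two here. Compound 3 `CO/N=C/c1ccccc1NCC1=NCCN1` has not been measured; it differs from compound 1 by a group of 4 heavy atoms (2 carbon, 1 nitrogen, 1 oxygen; no ring) in place of a group of 6 heavy atoms (3 carbon, 2 nitrogen, 1 oxygen; one five-membered aromatic ring with 3 hetero atoms), on an aromatic carbon. For the measured compounds named here, no measured pair shows this change, so only an expectation can be given. The step of a 1.5-fold lower number from compound 1 to compound 3 (0.17 log units; within the scatter) is expected to be small, within the usual scatter. Compound 3 is estimated at 450 nM, between 120 nM and 1700 nM.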

Compound 3, half-maximal effective concentration: 51.3 nM
Compound 3: middle estimate off by 8.8-fold (0.94 log units), on the high side; measured number outside the range, below it.
By their numbers in this assay, from the lowest: compounds 2 and 3 (each within the scatter of the next); then compound 1.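

In this assay this position proves sensitive to the group it carries: the open group with no ring in place of 3-methyl-1,2,4-oxadiazol-5-yl gives a 13-fold lower number from compound 1 to compound 3 (1.11 log units; beyond the scatter) and puts compound 3 within the scatter of compound 2, which keeps a ring here. A ring on this aromatic carbon is therefore not required for a low number. Nothing available here accounts for the size of this step.

Open, from the compounds shown here alone, is what the methyl on the oxime oxygen contributes, and whether a hydroxyl or a longer alkyl chain there would read the same. Also open, going by these compounds, is how a simple nitrile at this place would compare.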